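An amide in place of an ether on the shared core

This account rests on a few compounds, and the source may have more. Where it says the series, first, only, none or still open, it means among the compounds named here.

Compound 1 `Cc1nn(-c2ncnc3nc[nH]c23)c2c1C(OCc1ccc(Cl)cc1Cl)CC(=O)N2`: 243 nM
Compound 2 `Cc1nn(-c2ncnc3nc[nH]c23)c2c1C(OCc1ccccc1C#N)CC(=O)N2`: 127 nM
Compound 3 `Cc1nn(-c2ncnc3nc[nH]c23)c2c1C(OCc1ccc(C#N)cc1)CC(=O)N2`: 60 nM

Of the compounds shown here, three sharing one core have been measured in a functional assay on HEK293 cells for agonist activity at G-protein coupled receptor 39 (Homo sapiens), read by scintillation proximity assay and inositol phosphate accumulation, with a stated time of 75 min; on this read-out higher numbers stand for an effect only at larger amounts of compound and lower numbers for an effect already at smaller amounts. Compound 3 gives the lowest number of the three; its nearest neighbour is compound 2, and the step of a 2.1-fold lower number from compound 2 to compound 3 (0.33 log units; beyond the scatter) lies beyond the scatter, as does the step of a 4.1-fold lower number from compound 1 to compound 3 (0.61 log units; beyond the scatter). The step of a 1.9-fold lower number from compound 1 to compound 2 (0.28 log units; within the scatter) lies within the scatter. All three measured steps are exchanges of one aryl group for another on the benzyl ether.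

Compound 4 `Cc1nn(-c2ncnc3nc[nH]c23)c2c1C(NC(=O)Cc1cccs1)CC(=O)N2` departs from that series: (((thiophen-2-yl)methyl)carbonyl)amino in place of (4-cyanobenzyl)oxy on a saturated ring carbon. Among the compounds with values here, no measured step bears directly on this change, since the ether oxygen and the aromatic six-membered ring are both gone and an amide with a five-membered sulfur-containing ring takes their place. The aryl swaps seen so far moved the number only modestly, but a change of this kind is larger than any of them, so the outcome is uncertain in both directions. Compound 4 is therefore expected to give a somewhat higher number than compound 3, the estimated step being a 3.3-fold higher number from compound 3 to compound 4 (0.52 log units; beyond the scatter). The estimate for compound 4 in this assay is 200 nM, with a range from 40 nM to 1000 nM.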

Compound 4, half-maximal effective concentration: 244 nM
The estimate for compound 4 lay 1.2-fold (0.09 log units) below the measured number, and the stated range covers the measured number.
By their numbers in this assay, from the lowest: compound 3; then compounds 2, 1 and 4 (each within the scatter of the next).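

In this assay, the change from a benzyl ether to (((thiophen-2-yl)methyl)carbonyl)amino on the saturated ring carbon does not by itself set compound 4 apart from the ether series: a 1.0-fold higher number from compound 1 to compound 4 (0.00 log units; within the scatter) and a 1.9-fold higher number from compound 2 to compound 4 (0.28 log units; within the scatter) both lie within the scatter. Only the best of the ethers goes against this, with a 4.1-fold higher number from compound 3 to compound 4 (0.61 log units; beyond the scatter), so this position accepts an amide bearing a five-membered aromatic ring with sulfur and a hydrogen-bond donor while staying level with two of the three ethers, though it does not match the (4-cyanobenzyl)oxy group. No measurement at hand explains this outcome.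

On these data alone, the ether oxygen and the aryl group change together in compound 4, so it remains open how much of the step from the (4-cyanobenzyl)oxy group belongs to each; an amide carrying a 4-cyanophenyl ring, or a (thiophen-2-yl)methoxy ether, would separate the two. As far as these compounds go, it is equally open how this ring carbon would respond to a simple amine, a carboxylic acid or a longer chain on the amide carbonyl.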